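Removing One Hydroxy Group: Expected Effect on Binding

A few compounds are considered here, and "the series" means these few. Any claim that something is new, unique, unknown or untested is made for them only; others in the source may bear on it.

Compound 1, `C(=C1\CCN=C1c1cccnc1)\c1ccccc1`, in an assay for displacement of a labelled ligand from Nicotinic acetylcholine receptor alpha8 subunit (Periplaneta americana), read by scintillation counting, with a stated time of 2 h, at 24 degrees C (on this read-out higher numbers stand for weaker inhibition and lower numbers for stronger inhibition), gives > 10000 nM, a limit of the assay rather than a number.
Compound 2, `Oc1ccc(/C=C2\CCN=C2c2cccnc2)c(O)c1`, in this assay gives 120 nM.

Among the compounds with values here, of these two results, compound 2 holds the only actual number; the other sits at the limit of > 10000 nM in this assay, at which 1 of the 2 values shown sits. Compound 2 therefore stands alone as the measured point from which to reason. Compound 3, `Oc1ccc(/C=C2\CCN=C2c2cccnc2)cc1`, is not yet measured in this assay. It differs from compound 2 by a single change: hydrogen in place of hydroxy on an aromatic carbon. Within the data shown here, no measured pair differing in just one place is available, so the size of this step is not known. Compound 1 carries no hydroxy group at all and gives only the limit > 10000 nM, so taking away one of the two hydroxy groups of compound 2 is expected to weaken binding, by a moderate step beyond the usual scatter. Compound 3 is expected to give 600 nM, within 150 nM to 3000 nM. The expected step is a 5.0-fold higher number from compound 2 to compound 3 (0.70 log units; beyond the scatter).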

Compound 3, half-maximal inhibitory concentration: 310 nM
Estimate against measurement, compound 3: 1.9-fold (0.29 log units) above; low and high end bracket the measured number.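

Taking away the hydroxy group that lies ortho to a large group costs only a modest amount of binding in this assay: the change gives a 2.6-fold higher number from compound 2 to compound 3 (0.41 log units; beyond the scatter). The value for compound 1 is a limit of the assay, not a number: the limit of > 10000 nM in this assay, at which 1 of the 3 values shown sits. Even so, hydroxy in place of hydrogen on the ring of compound 1 gives an at least 32-fold lower number from compound 1 to compound 3 (1.50 log units; beyond the scatter), so among these compounds the hydroxy group kept in compound 3 accounts for a much larger step than the one removed.

The compounds shown leave open whether the hydroxy group kept in compound 3 could give way to a methoxy group, an amine or a fluorine atom and still hold this binding. They also leave open how a compound carrying only the other hydroxy group, the one ortho to a large group, would compare.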